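This account rests on a few compounds, and the source may have more. Where it says the series, first, only, none or still open, it means among the compounds named here.

Measured compounds in a functional assay on MGC-803 cells (Homo sapiens) for antiproliferative activity, read by MTT assay, with a stated time of 72 h; a lower number here means a stronger inhibitor, a higher number a weaker inhibitor:
Compound 1 `CCCSc1nc(N/N=C/c2ccccc2F)c2nnn(Cc3ccccc3)c2n1` gives only a limit, > 64000 nM.
Compound 2 `CCCSc1nc(N/N=C(\C)c2ccccc2O)c2nnn(Cc3ccco3)c2n1` gives 4760 nM.
Compound 3 `CCCSc1nc(N/N=C/c2cc(OC)c(OC)c(OC)c2)c2nnn(Cc3ccccc3)c2n1` gives 9410 nM.

Compound 1 therefore stands at the edge of what this assay can report: its value is a limit, not a number, as shown by the limit of > 64000 nM in this assay, at which 1 of the 3 values shown sits. Compound 4 `CCCSc1nc(N/N=C/c2ccc([N+](=O)[O-])cc2)c2nnn(Cc3ccccc3)c2n1` has not yet been measured. It differs from compound 1 in one place: 4-nitrophenyl in place of 2-fluorophenyl on a carbon with a double bond to nitrogen. For the measured compounds named here, no two measured compounds differ in only one place, so there is no measured step to lean on; compound 2 and compound 3 simply show that other members do reach measurable numbers in this assay. The step is expected to be an at least 2.1-fold lower number from compound 1 to compound 4 (0.32 log units; beyond the scatter), a gain that may exceed the scatter but remains uncertain. Compound 4 is thus estimated at 30000 nM, lying between 8000 nM and 100000 nM, with a real chance that only a limit is reported once more.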

Compound 4, half-maximal inhibitory concentration: 10100 nM
For compound 4 the middle estimate is 3.0-fold (0.47 log units) above the measured one, within the range that was stated.
By their numbers in this assay, from the lowest: compounds 2, 3 and 4 (each within the scatter of the next, the first and the last beyond it). At a limit, above all of these: compound 1.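

For the compounds shown here, on the carbon with a double bond to nitrogen, 4-nitrophenyl in place of 2-fluorophenyl gives the first measured step at this position in this assay (an at least 6.3-fold lower number from compound 1 to compound 4 (0.80 log units; beyond the scatter)). Compound 1 gives only a limit, so this step marks the least possible change and not its true size: the limit of > 64000 nM in this assay, at which 1 of the 4 values shown sits. The six-membered aromatic ring of carbon stays, so the change lies in what that ring carries. As far as these compounds go, what remains open is whether the gain comes from adding the nitro group or from losing the fluorine. How a 4-aminophenyl group would behave at the same place is also unknown.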